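The compounds below may be only part of what the source reports. "The series", "measured", "known", "first", "only" and "open" are said of these compounds alone.

Compound 3, whose structure is `CCN1CCN(c2cc(C)c3cc(NC(=O)c4ccc(Cl)cc4)ccc3n2)CC1`, gives the lowest number of the three measured compounds in a functional assay on MCF7 cells (Homo sapiens) for antiproliferative activity, read by MTT assay, with a stated time of 72 h (a lower number here means a stronger inhibitor, a higher number a weaker inhibitor), namely 1530 nM. Compound 2, with structure `Cc1cc(N2CCN(C)CC2)nc2ccc(NC(=O)c3ccc(Cl)c(Cl)c3)cc12`, gives 3000 nM in this assay, which is within the scatter of compound 3. Within the data shown here, compound 1, with structure `CCN1CCN(c2cc(C)c3cc(NC(=O)c4ccccc4)ccc3n2)CC1`, gives 14200 nM, and the step of a 9.3-fold lower number from compound 1 to compound 3 (0.97 log units; beyond the scatter) is the only measured step that bears on the change now considered: a chloro entering for a hydrogen on an aromatic carbon. Compound 4, whose structure is `CCN1CCN(c2cc(C)c3cc(NC(=O)c4ccc(Cl)c(Cl)c4)ccc3n2)CC1`, differs from compound 3 by chloro in place of hydrogen on an aromatic carbon. The second chloro enters ortho to a chloro group already in place, so the measured step from compound 1 to compound 3 need not repeat at its full size. Compound 2 already carries a 3,4-dichlorophenyl group and its value sits within the scatter of compound 3, which argues for a small step. Compound 4 is therefore expected to show a step of a 1.0-fold lower number from compound 3 to compound 4 (0.01 log units; within the scatter), not beyond the scatter. Compound 4 is estimated at 1500 nM, within a range from 600 nM to 4000 nM.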

Compound 4, half-maximal inhibitory concentration: 1380 nM
Compound 4: the middle estimate sits 1.1-fold (0.04 log units) above what was measured; the range from low to high includes it.
By their numbers in this assay, from the lowest: compounds 4, 3 and 2 (each within the scatter of the next, the first and the last beyond it); then compound 1.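

In this assay chloro in place of hydrogen on the 4-chlorophenyl group gives a 1.1-fold lower number from compound 3 to compound 4 (0.04 log units; within the scatter) and so does not repeat a 9.3-fold lower number from compound 1 to compound 3 (0.97 log units; beyond the scatter) on the phenyl group. Taken whole, 3,4-dichlorophenyl in place of phenyl on the carbonyl carbon gives a 10-fold lower number from compound 1 to compound 4 (1.01 log units; beyond the scatter) with nearly all of it already present in compound 3. Among these compounds, with the 3,4-dichlorophenyl group held fixed, methyl in place of hydrogen on the saturated chain carbon bound to the ring amine nitrogen gives a 2.2-fold lower number from compound 2 to compound 4 (0.34 log units; beyond the scatter) and is the first single change read at that end of the molecule.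

Going by these compounds, whether a 3-chlorophenyl group alone would match the 4-chlorophenyl group stays open, as does the outcome of placing a methoxy group or an amine at this position instead of chloro. Nothing measured here accounts for these steps.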